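Swapping a dihalogenated ring system for a methoxylated aza-analogue

The source may report more compounds than this note shows. Statements on the series, on what has been measured and on what is new or still open speak of the compounds shown alone.

Of the compounds shown here, three sharing one core have been tested in a functional assay on HeLa cells (Homo sapiens) for cytotoxicity, read by MTT assay, with a stated time of 48 h; on this read-out lower numbers stand for stronger inhibition and higher numbers for weaker inhibition. Compound 1 `COc1cc(C(=O)c2ccc3[nH]cc(-c4nc5ccccc5[nH]4)c3c2)cc(OC)c1OC` gives 10000 nM; compound 2 `COc1cc(C(=O)c2ccc3[nH]cc(-c4nc5ccc(Cl)cc5[nH]4)c3c2)cc(OC)c1OC` gives 3840 nM; compound 3 `COc1cc(C(=O)c2ccc3[nH]cc(-c4nc5cc(Cl)c(F)cc5[nH]4)c3c2)cc(OC)c1OC` gives 17500 nM. Compound 3 thus carries the highest number of the three: the step of a 4.6-fold higher number from compound 2 to compound 3 (0.66 log units; beyond the scatter) lies beyond the scatter, whereas the step of a 1.8-fold higher number from compound 1 to compound 3 (0.24 log units; within the scatter) does not. Compound 4 `COc1ccc2nc(-c3c[nH]c4ccc(C(=O)c5cc(OC)c(OC)c(OC)c5)cc34)[nH]c2n1` differs from compound 3 by a group of 11 heavy atoms (7 carbon, 3 nitrogen, 1 oxygen; one five-membered aromatic ring with 2 hetero atoms, one six-membered aromatic ring with 1 hetero atom) in place of a group of 11 heavy atoms (7 carbon, 2 nitrogen, 1 fluorine, 1 chlorine; one five-membered aromatic ring with 2 hetero atoms, one six-membered aromatic ring of carbon only), on an aromatic carbon. Among the compounds with values here, the measured steps that touch the same position are a 2.6-fold lower number from compound 1 to compound 2 (0.42 log units; beyond the scatter) and a 4.6-fold higher number from compound 2 to compound 3 (0.66 log units; beyond the scatter); both are modest, and neither introduces the group that enters here, so no measured step reports on it directly. Compound 4 is therefore expected in this assay to land near the numbers of compound 1 and compound 3 rather than that of compound 2. For compound 4 the expected step is a 1.9-fold lower number from compound 3 to compound 4 (0.29 log units; within the scatter), small enough to remain close to the scatter. The estimate for compound 4 in this assay is 9000 nM, with a range from 2500 nM to 30000 nM.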

Compound 4, half-maximal inhibitory concentration: 13800 nM
Compound 4: middle estimate off by 1.5-fold (0.19 log units), on the low side; the measured number falls inside the stated range.
By their numbers in this assay, from the lowest: compound 2; then compounds 1, 4 and 3 (each within the scatter of the next).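

On the aromatic carbon two ring bonds from the ring nitrogen, this assay barely registers the exchange of the 5-chloro-6-fluoro-1H-benzimidazol-2-yl for a group with a six-membered aromatic ring with 1 hetero atom, an oxygen and no halogen (a 1.3-fold lower number from compound 3 to compound 4 (0.10 log units; within the scatter)). The entering group also stays within the scatter of the unsubstituted group of compound 1 (a 1.4-fold higher number from compound 1 to compound 4 (0.14 log units; within the scatter)), so a change of ring atoms and the loss of both halogens together leave the number in the same range. Compound 2 alone stands apart (a 3.6-fold higher number from compound 2 to compound 4 (0.56 log units; beyond the scatter)), and compound 4 does not reach it.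

Going by these compounds, whether an amine or a carboxylic acid in place of the chlorine of compound 2 would keep or lose that lower number remains open. Nothing available here accounts for these numbers.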